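From compound 2 to compound 4: an aryl exchange

This account rests on a few compounds, and the source may have more. Where it says the series, first, only, none or still open, it means among the compounds named here.

Of the compounds shown here, three have numbers so far in a functional assay on SW-620 cells (Homo sapiens) for inhibition, read by MTT assay, with a stated time of 72 h (a higher number here means a weaker inhibitor, a lower number a stronger inhibitor), and share one core. Compound 1 (`COc1cc(NC(C)CCCNC(=O)Nc2ccc(Br)cc2)c2ncccc2c1`) gives 23000 nM in this readout. Compound 3 (`COc1cc(NC(C)CCCNC(=O)Nc2cc(C(F)(F)F)cc(C(F)(F)F)c2)c2ncccc2c1`) gives 3900 nM as the lowest number of the three. Compound 2 (`COc1cc(NC(C)CCCNC(=O)NNC(=O)Nc2ccc(Cl)cc2)c2ncccc2c1`) gives 48000 nM as the highest of the three, which makes it the weakest inhibitor of this small set.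

Compound 4 (`COc1cc(NC(C)CCCNC(=O)NNC(=O)Nc2cccc(F)c2)c2ncccc2c1`) is still unmeasured. It has 3-fluorophenyl in place of 4-chlorophenyl on an amide-type nitrogen and is otherwise the same as compound 2.

Among the compounds with values here, only one measured step touches this place, and it is modest: a 2.1-fold higher number from compound 1 to compound 2 (0.32 log units; beyond the scatter) (((4-chlorophenyl)carbamoyl)amino in place of 4-bromophenyl). That step changes more than the aryl group, so it is only a loose guide. Within the data shown here, no measured step exchanges one aryl group for another while the rest stays fixed. Compound 3 at 3900 nM does show that numbers well below that of compound 2 occur in this series, so any drift is expected to be downward.

The expected change is small (a 1.3-fold lower number from compound 2 to compound 4 (0.10 log units; within the scatter)), and no step beyond the scatter is expected. The estimated value for compound 4 is 38000 nM (range 15000 nM to 95000 nM).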

Compound 4, half-maximal inhibitory concentration: 9500 nM
Beside the measured number, compound 4's estimate is 4.0-fold (0.60 log units) above it; the measured number lies below the stated range.
By their numbers in this assay, from the lowest: compound 3; then compound 4; then compound 1; then compound 2.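

In this assay, within the data shown here, the aryl exchange on an amide-type nitrogen gives a 5.1-fold lower number from compound 2 to compound 4 (0.70 log units; beyond the scatter), the only measured step here that changes the aryl group alone, so this position responds beyond the scatter even though both groups have the same heavy-atom count and no hydrogen-bond donors or acceptors. The comparison with 4-bromophenyl also changes direction: a 2.1-fold higher number from compound 1 to compound 2 (0.32 log units; beyond the scatter) with ((4-chlorophenyl)carbamoyl)amino, but a 2.4-fold lower number from compound 1 to compound 4 (0.38 log units; beyond the scatter) with ((3-fluorophenyl)carbamoyl)amino, so the outcome of this longer replacement depends on the aryl group it carries. Nothing available bears on the reason for either result.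

The exchange alters the halogen and its place on the ring together, and the compounds shown do not separate these two changes. Also open, as far as these compounds go, is how far the number moves with an unsubstituted phenyl, or with a nitrile or a carboxylic acid on the aryl group, in this assay, and whether any such group on this longer chain reaches the number of compound 3 at 3900 nM.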